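From Benzyl(ethyl)amide to 2-Chlorobenzylamide

The source may report more compounds than this note shows. Statements on the series, on what has been measured and on what is new or still open speak of the compounds shown alone.

The shared core carries a pyrazole-type scaffold only as far as the data show it; what varies is the amide. Compound 1 `CCN(Cc1ccccc1)C(=O)c1nn(-c2ccc(F)cc2)c(OC[C@@H](O)C[C@@H](O)CC(=O)O)c1C(C)C` gives 2660 nM in a functional assay on L6 cells (Rattus norvegicus) for inhibition (a higher number here means a weaker inhibitor, a lower number a stronger inhibitor), the lowest of the two numbers in hand. Going by the values given here, compound 2 `COc1cccc(CNC(=O)c2nn(-c3ccc(F)cc3)c(OC[C@@H](O)C[C@@H](O)CC(=O)O)c2C(C)C)c1` gives 8750 nM, and the step of a 3.3-fold higher number from compound 1 to compound 2 (0.52 log units; beyond the scatter) is the only measured change at this position, both exchanging the benzyl(ethyl)amino group and removing its ethyl. Compound 3 `COc1ccccc1CNC(=O)c1nn(-c2ccc(F)cc2)c(OC[C@@H](O)C[C@@H](O)CC(=O)O)c1C(C)C` has "not determined" (no result reported). Compound 4 `CC(C)c1c(C(=O)NCc2ccccc2Cl)nn(-c2ccc(F)cc2)c1OC[C@@H](O)C[C@@H](O)CC(=O)O` differs from compound 1 by (2-chlorobenzyl)amino in place of benzyl(ethyl)amino on a carbonyl carbon. Among the compounds with values here, since the one comparable step weakened inhibition, a similar loss is expected here, giving a 2.3-fold higher number from compound 1 to compound 4 (0.35 log units; beyond the scatter). Compound 4 is therefore estimated at 6000 nM, between 2200 nM and 16000 nM.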

Compound 4, half-maximal inhibitory concentration: 8450 nM
Beside the measured number, compound 4's estimate is 1.4-fold (0.15 log units) below it; the range from low to high includes it.
By their numbers in this assay, from the lowest: compound 1; then compounds 4 and 2 (each within the scatter of the next).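

In this assay, a second amide without the ethyl group also gives a weaker inhibitor than the benzyl(ethyl)amide: a 3.2-fold higher number from compound 1 to compound 4 (0.50 log units; beyond the scatter). The ring substituent makes no visible difference between the two such amides, as 2-chlorophenyl in place of 3-methoxyphenyl gives a 1.0-fold lower number from compound 2 to compound 4 (0.02 log units; within the scatter). Nothing available explains either result. The compounds shown leave open whether the loss tracks the missing ethyl or the ring substituents, since both change together from compound 1. A plain benzylamino group or a (2-chlorobenzyl)(ethyl)amino group would separate the two.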